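Furan-2-yl to phenyl in the bile acid receptor series

A few compounds are considered here, and "the series" means these few. Any claim that something is new, unique, unknown or untested is made for them only; others in the source may bear on it.

Of the compounds shown here, three of the shared core have been measured in an assay on isolated protein for agonist activity at Bile acid receptor (Homo sapiens), read by AlphaScreen, with a stated time of 30 min; a higher number here means a larger maximal response, a lower number a smaller maximal response. Compound 1 `Cc1ccccc1-n1nc(C)c2c1NC(=O)[C@H](C)S[C@@H]2c1ccc(-c2ccoc2)cc1` gives 40%, compound 2 `COc1cccc(-c2ccc([C@H]3S[C@@H](C)C(=O)Nc4c3c(C)nn4-c3ccccc3C)cc2)c1` gives 41%, and compound 3 `Cc1ccccc1-n1nc(C)c2c1NC(=O)[C@H](C)S[C@@H]2c1ccc(-c2ccco2)cc1` gives 32%. Compound 3 holds the lowest of the three numbers, but its gaps to the others, a number 8 percentage points lower from compound 1 to compound 3 (within the scatter) and a number 9 percentage points lower from compound 2 to compound 3 (within the scatter), are both within the scatter, so the three stand on one level.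

Compound 4 `Cc1ccccc1-n1nc(C)c2c1NC(=O)[C@H](C)S[C@@H]2c1ccc(-c2ccccc2)cc1` is the next member. (phenyl in place of furan-2-yl on an aromatic carbon). Within the data shown here, two measured steps bear on it: the six-membered carbon ring of compound 2 against the furan-2-yl of compound 3, a number 9 percentage points lower from compound 2 to compound 3 (within the scatter), and the two furans, a number 8 percentage points lower from compound 1 to compound 3 (within the scatter). Neither step left the scatter, and the closest analogue of the incoming phenyl, compound 2, differs from compound 3 by only a within-scatter margin. The expected step in this assay is therefore a number 6 percentage points higher from compound 3 to compound 4 (within the scatter), at most a return toward the level of compound 2, with no direction claimed beyond the scatter. Compound 4 is estimated to give 38%, ranging from 25% to 52%.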

Compound 4, largest response reached (reported as efficacy), in percent of the reference or control that the assay uses: 24%
Compound 4: middle estimate off by 14 percentage points, on the high side, and the stated range ends above it.
By their numbers in this assay, from the lowest: compounds 4, 3, 1 and 2 (each within the scatter of the next, the first and the last beyond it).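

Among these compounds, with phenyl on the aromatic carbon para to a large group, this assay gives the first steps beyond the scatter in this set: a number 16 percentage points lower from compound 1 to compound 4 (beyond the scatter) for phenyl in place of furan-3-yl, and a number 17 percentage points lower from compound 2 to compound 4 (beyond the scatter) for hydrogen in place of methoxy. The second step shows that the methoxy on the phenyl ring matters at this position, since the unsubstituted phenyl does not hold the level of the 3-methoxyphenyl. The step of a number 8 percentage points lower from compound 3 to compound 4 (within the scatter) for phenyl in place of furan-2-yl leaves compound 3 unseparated from each of the other compounds, so furan-2-yl sits on one level with both the best and the worst groups here.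

Still open, going by these compounds, is whether an amine or a carboxylic acid in place of that methoxy would keep or shift the maximal response. No supporting data bear on these steps.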